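Swapping a Furan for an Imidazole on a Shared Core

The source may report more compounds than this note shows. Statements on the series, on what has been measured and on what is new or still open speak of the compounds shown alone.

Of the compounds shown here, three built on a shared core have been tested in a functional assay on CHO-K1 cells for antagonist activity at adenosine receptor A1 (Homo sapiens), read by a beta-galactosidase reporter and cAMP accumulation, with stated times of 15 min and 6 h; a higher number here means a weaker inhibitor, a lower number a stronger inhibitor. Compound 1 `Cc1ccc(-c2nc(N)c3cc(Cc4ccccc4F)sc3n2)o1` returns not a number but a limit of the assay, < 16 nM. Compound 3 `C=C(c1ccccc1)c1cc2c(N)nc(-c3nc(C)cs3)nc2s1` likewise returns only a limit, > 594 nM. Going by the values given here, compound 2 `CC(C)c1ccc(-c2nc(N)c3cc(Cc4ccccc4)sc3n2)o1` is the single compound of the three with a measured number in this assay, 283 nM. The other two entries are limits: one is the limit of < 16 nM in this assay, at which 1 of the 3 values shown sits, the other is the limit of > 594 nM in this assay, at which 1 of the 3 values shown sits. Compound 2 thus supplies the only firm point and serves as the starting place for the step to compound 4 `Cn1cnc(-c2nc(N)c3cc(Cc4ccccc4)sc3n2)c1`, which has not yet been measured.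

The change from compound 2 to compound 4 is 1-methyl-1H-imidazol-4-yl in place of 5-isopropylfuran-2-yl on an aromatic carbon.

Among the compounds with values here, no two measured compounds differ in a single place, so there is no measured step to lean on for this change. The expectation is nevertheless that the step from compound 2 to compound 4 will run toward weaker inhibition, by an amount beyond the usual scatter, a 2.5-fold higher number from compound 2 to compound 4 (0.39 log units; beyond the scatter). Compound 4 is accordingly estimated at 700 nM in this assay, with a range from 150 nM to 3000 nM, and it is expected that the reported result may well turn out to be a limit rather than a number.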

Compound 4, inhibition constant: 2330 nM
Compound 4: the middle estimate sits 3.3-fold (0.52 log units) below what was measured; the range from low to high includes it.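

Going by these compounds alone, this step is the first comparison between two compounds on the shared core that differ in one place only. In this assay it reads an 8.2-fold higher number from compound 2 to compound 4 (0.92 log units; beyond the scatter), which shows that the group on the aromatic carbon between two ring nitrogen atoms has a clear bearing on this read-out, and that 1-methyl-1H-imidazol-4-yl is not an even exchange for 5-isopropylfuran-2-yl on this core. The swap alters several things at once, since the ring gains a hetero atom, the hydrogen-bond acceptors rise from one to two, and the heavy atoms fall from eight to six, and nothing measured here explains why the number rises.

As far as these compounds go, with one step in hand, it stays open which part of the change carries the effect: the loss of the isopropyl group, the exchange of the furan ring for an imidazole, or both together. A plain furan-2-yl group with no isopropyl on it, or an imidazole ring bearing an isopropyl group in place of the methyl, would begin to pull these two parts apart.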